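The compounds below may be only part of what the source reports. "The series", "measured", "known", "first", "only" and "open" are said of these compounds alone.

Measured so far in a functional assay on HCT-15 cells (Homo sapiens) for cytotoxicity, read by CCK-8 assay; a lower number here means a stronger inhibitor, a higher number a weaker inhibitor:
Compound 1 `Oc1ccc(-c2cc(-c3ccco3)cc(-c3ccccc3O)n2)cc1`: in this assay compound 1 gives > 50000 nM, a limit of the assay.
Compound 2 `Oc1ccc(-c2cc(-c3ccoc3)cc(-c3ccccc3O)n2)cc1`: in this assay compound 2 gives > 50000 nM, likewise a limit.

Going by the values given here, compound 2 stands only at a limit; the one further value shown is a limit as well, so no ranking follows. The step from compound 1 to compound 2 in this assay, a step that the two limits leave unreadable from compound 1 to compound 2, cannot be read because of the limit of > 50000 nM in this assay, at which 2 of the 2 values shown sit. Compound 3 `Oc1ccc(-c2cc(-c3ccccn3)cc(-c3ccccc3O)n2)cc1` differs from compound 2 by pyridin-2-yl in place of furan-3-yl on an aromatic carbon. Among the compounds with values here, only that unreadable step bears on this change; nothing measured points beyond the limit. For compound 3 no gain beyond the scatter is expected, and the estimated step that the limit leaves unreadable from compound 2 to compound 3 is taken as staying at the limit. Compound 3 is expected at 60000 nM, range 20000 nM to 200000 nM.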

Compound 3, half-maximal inhibitory concentration: > 50000 nM
Compound 3: no number, only a limit; the forecaster's own chance of this, stated with the estimate: 80%; the middle value is on the limit's open side.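

No step among compound 1, compound 2 and compound 3 can be read in this assay, because each value is a limit: the limit of > 50000 nM in this assay, at which 3 of the 3 values shown sit.

The compounds shown leave open whether any group in that place on the shared core gives a readable value.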